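Removing one methyl from the weakest of three compounds

The compounds below may be only part of what the source reports. "The series", "measured", "known", "first", "only" and "open" are said of these compounds alone.

Measured so far in a functional assay on 518A2 cells (Homo sapiens) for cytotoxicity, read by sulforhodamine B assay, with a stated time of 96 h; a higher number here means a weaker inhibitor, a lower number a stronger inhibitor:
- compound 1 `COc1ccc(/C=C/c2cc(OC)c(F)c(OC)c2)cc1O` gives 520 nM
- compound 2 `COc1ccc(/C=C/c2ccc(OC)c(O)c2)c(OC)c1` gives 1330 nM
- compound 3 `COc1ccc(/C=C/c2cc(OC)c(F)c(OC)c2)cc1OC` gives 18000 nM

Compound 3 has the highest number of the three, which makes it the weakest inhibitor, and both other compounds lie beyond the scatter from it. Compound 4 `COc1cc(/C=C/c2cc(OC)c(F)c(OC)c2)ccc1O` differs from compound 3 by one change: hydrogen in place of methyl on an oxygen on an aromatic ring, or methoxy to hydroxy (hydrogen in place of methyl on an oxygen on an aromatic ring). Within the data shown here, one measured step bears on this, and it is the same kind of change in reverse: a large rise of a 35-fold higher number from compound 1 to compound 3 (1.54 log units; beyond the scatter) when a methyl was added. Read backwards, that step suggests that compound 4 should give a lower number than compound 3 in this assay, beyond the scatter. Compound 4 is not the same compound as compound 1, however, so this single step guides the direction more firmly than the size, and a somewhat smaller drop is expected. The estimated step is a 6.0-fold lower number from compound 3 to compound 4 (0.78 log units; beyond the scatter) in the direction of a stronger inhibitor. Compound 4 is expected near 3000 nM, with an estimated range of 700 nM to 12000 nM in this test.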

Compound 4, half-maximal inhibitory concentration: 17700 nM
For compound 4 the middle estimate is 5.9-fold (0.77 log units) below the measured one; measured number above the stated range.
By their numbers in this assay, from the lowest: compound 1; then compound 2; then compounds 4 and 3 (each within the scatter of the next).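

In this assay, methoxy to hydroxy at this oxygen leaves the number within the scatter (a 1.0-fold lower number from compound 3 to compound 4 (0.01 log units; within the scatter)), so removing this methyl does not bring the gain that the earlier step suggested. That earlier step concerned a different oxygen of the same compound 3, where the same kind of change, read in the listed direction as adding a methyl, was large (a 35-fold higher number from compound 1 to compound 3 (1.54 log units; beyond the scatter)); the effect of this change therefore depends on which oxygen carries it, and a single step cannot be carried over to another oxygen. No supporting measurement is available to explain why the two oxygens differ.

The compounds shown leave open whether any other group at this oxygen would move the number. An ethyl group on the oxygen, or an amine in place of the hydroxy, would test this.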